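Replacing the Pyrazole Hydrazone with a Pyridine

A few compounds are considered here, and "the series" means these few. Any claim that something is new, unique, unknown or untested is made for them only; others in the source may bear on it.

Compound 1, `NS(=O)(=O)c1ccc(Nc2nc(N/N=C/c3ccc(C(F)(F)F)cc3)nc(Nc3ccccc3)n2)cc1`: 12300 nM
Compound 2, `Cc1nn(-c2ccccc2)cc1/C=N/Nc1nc(Nc2ccccc2)nc(Nc2ccc(S(N)(=O)=O)cc2)n1`: > 100000 nM

In a functional assay on NCI/ADR-RES cells (Homo sapiens) for inhibition, read by sulforhodamine B assay, with a stated time of 48 h (a higher number here means a weaker inhibitor of growth, a lower number a stronger inhibitor of growth), compound 1 gives 12300 nM. For compound 2 this assay reports only a limit, > 100000 nM, which is the limit of > 100000 nM in this assay, at which 1 of the 2 values shown sits. Among the compounds with values here, the one measured step that bears on the next change is an at least 8.1-fold higher number from compound 1 to compound 2 (0.91 log units; beyond the scatter), where a six-membered ring gave way to the pyrazole. Compound 3, `NS(=O)(=O)c1ccc(Nc2nc(N/N=C/c3ccccn3)nc(Nc3ccccc3)n2)cc1`, carries pyridin-2-yl in place of 3-methyl-1-phenyl-1H-pyrazol-4-yl on a carbon with a double bond to nitrogen. Bringing back a six-membered ring is expected to recover part of that loss. Compound 3 is therefore estimated at 30000 nM, between 8000 nM and 100000 nM, an expected step of an at least 3.3-fold lower number from compound 2 to compound 3 (0.52 log units; beyond the scatter).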

Compound 3, concentration for 50% growth inhibition: 2750 nM
For compound 3 the middle estimate is 11-fold (1.04 log units) above the measured one, outside the stated range (below it).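

In this assay, pyridin-2-yl on this carbon gives an at least 36-fold lower number from compound 2 to compound 3 (1.56 log units; beyond the scatter), though compound 2 has only a limit and no exact number: the limit of > 100000 nM in this assay, at which 1 of the 3 values shown sits. Pyridin-2-yl also improves on the other six-membered group, with a 4.5-fold lower number from compound 1 to compound 3 (0.65 log units; beyond the scatter). A six-membered ring alone therefore does not fix the result at this position, since the two such groups shown differ beyond the scatter.

Going by these compounds, what remains open is whether the ring nitrogen or the loss of trifluoromethyl matters more. Unsubstituted phenyl or pyridin-3-yl on this carbon would help separate the two.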